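Benzoxazole for Benzothiazole on an Inactive Amide Scaffold

This account rests on a few compounds, and the source may have more. Where it says the series, first, only, none or still open, it means among the compounds named here.

Compound 1 `CCOc1cc(C(=O)Nc2ccc(Cl)c(-c3nc4ccccc4s3)c2)cc(OCC)c1OCC` was tested in a functional assay on Shh Light II cells for inhibition of Sonic hedgehog protein (Mus musculus), read by reporter gene assay, with a stated time of 48 h, in the presence of a further agent that is not named here (a higher number here means a weaker inhibitor, a lower number a stronger inhibitor), and compound 1 gave "not active" (no number reported), so no single number places it on the scale. Two further compounds, which differ from compound 1 at more than one place, give numbers: in this assay compound 2 `O=C(Nc1ccc(Cl)c(-c2nc3ccccc3[nH]2)c1)c1ccc(F)cc1` gives 251 nM, and in this assay compound 3 `O=C(Nc1ccc(Cl)c(-c2nc3ccccc3[nH]2)c1)c1cccc(C(F)(F)F)c1` gives 119 nM. Within the data shown here, since compound 1 itself has no number, no measured step can be stated from it; compound 1 therefore stands as the weaker partner with respect to compound 2 and compound 3.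

Compound 4 `CCOc1cc(C(=O)Nc2ccc(Cl)c(-c3nc4ccccc4o3)c2)cc(OCC)c1OCC` is the unmeasured neighbour of compound 1. It differs from compound 1 by one change, (1,3-benzoxazol-2-yl in place of 1,3-benzothiazol-2-yl on an aromatic carbon). Among the measured compounds shown here, no measured pair shows what this change does in this assay, and the starting point is a compound without activity, so the expectation is that compound 4 stays weak, with no step beyond the scatter that would bring it near compound 2 or compound 3. Compound 4 is estimated at 8000 nM in this assay, within a range of 2000 nM to 30000 nM, and it is expected that the assay may again report only a limit.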

Compound 4, half-maximal inhibitory concentration: "not active" (no number reported)
Compound 4: no number reported; the estimate stays without a comparison.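

In this assay compound 1 gives "not active" (no number reported) and compound 4 gives "not active" (no number reported), so no step can be read between compound 1 and compound 4. The compounds shown leave open what 1,3-benzoxazol-2-yl in place of 1,3-benzothiazol-2-yl does to potency in this assay. No measurement shown bears on this result.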